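Phenyl to cyclohexyl on the ring amide nitrogen

The compounds below may be only part of what the source reports. "The series", "measured", "known", "first", "only" and "open" are said of these compounds alone.

Measured compounds:
compound 1, `O=C1COc2ccc(-c3cccc(NS(=O)(=O)c4ccc(F)cc4)c3)cc2N1c1ccccc1`: 17700 nM
compound 2, `O=C1COc2ccc(-c3cnc(Cl)c(NS(=O)(=O)c4ccc(F)cc4)c3)cc2N1c1ccc(F)cc1`: a limit, > 40000 nM
compound 3, `O=C1COc2ccc(-c3ccc(O)cc3)cc2N1`: a limit, > 40000 nM

Among the compounds with values here, in a functional assay on HeLa cells (Homo sapiens) for antiproliferative activity, read by MTT assay, with a stated time of 72 h (a lower number here means a stronger inhibitor, a higher number a weaker inhibitor), compound 1 gives 17700 nM, the only number among the three and a weak one. Compound 2 returns only the limit > 40000 nM. Compound 3 also returns only the limit > 40000 nM. Within the data shown here, because of the limit of > 40000 nM in this assay, at which 2 of the 3 values shown sit, no step between measured compounds can be given a size, so compound 1 stands alone as the one compound with a number, and the two limits say only that compound 2 and compound 3 did not reach a measurable value.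

Compound 4, `O=C1COc2ccc(-c3cccc(NS(=O)(=O)c4ccc(F)cc4)c3)cc2N1C1CCCCC1`, differs from compound 1 in one place: cyclohexyl in place of phenyl on an amide-type nitrogen in a ring. Among the measured compounds shown here, no measured step bears on this change, so nothing beyond the scatter is expected, in either direction. Compound 4 is expected at 20000 nM, with a range from 7000 nM to 50000 nM. The implied step, a 1.1-fold higher number from compound 1 to compound 4 (0.05 log units; within the scatter), is expected to stay within the scatter, with a real chance that only a limit is returned.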

Compound 4, half-maximal inhibitory concentration: 10800 nM
Compound 4: the middle estimate sits 1.9-fold (0.27 log units) above what was measured, within the range that was stated.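

In this assay, cyclohexyl in place of phenyl on the amide-type nitrogen in a ring gives a 1.6-fold lower number from compound 1 to compound 4 (0.21 log units; within the scatter), so compound 1 and compound 4 cannot be told apart. Within the data shown here, this is the first readable step, and it is a step at this position. For this one pair, a non-aromatic ring of carbon only serves as well as a six-membered aromatic ring of carbon only, and the value stays measurable, though both compounds remain weak. As far as these compounds go, what an open chain such as a butyl group, or a cyclohexyl ring carrying an amine or a carboxylic acid, would do on this nitrogen remains open. Steps to the other compounds shown cannot be read: the limit of > 40000 nM in this assay, at which 2 of the 4 values shown sit.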